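The source may report more compounds than this note shows. Statements on the series, on what has been measured and on what is new or still open speak of the compounds shown alone.

Measured in a functional assay on MCF7 cells (Homo sapiens) for antiproliferative activity, read by MTT assay, with a stated time of 48 h; on this read-out lower numbers stand for stronger inhibition and higher numbers for weaker inhibition:
- Compound 1 `CC[C@@H](C)[C@H](NC(=O)c1ccc(Oc2nc3ccccc3nc2C)cc1)C(=O)OC`: 36100 nM
- Compound 2 `COC(=O)CNC(=O)c1ccc(Oc2nc3ccccc3nc2NC(C)(C)C)cc1`: > 50000 nM (a limit of the assay)
- Compound 3 `COC(=O)[C@H](C)NC(=O)c1ccc(Oc2nc3ccccc3nc2NC(C)(C)C)cc1`: 38400 nM

Among the compounds with values here, compound 3 and compound 1 hold the only true numbers, and these lie within the scatter of each other. Compound 2 rests at the limit of > 50000 nM in this assay, at which 1 of the 3 values shown sits.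

Compound 4 `CC[C@@H](C)[C@H](NC(=O)c1ccc(Oc2nc3ccccc3nc2NC(C)(C)C)cc1)C(=O)OC` differs from compound 3 by sec-butyl in place of methyl on a saturated chain carbon bound to an amide-type nitrogen and a carbonyl carbon. Within the data shown here, one measured step bears on this place: an at least 1.3-fold lower number from compound 2 to compound 3 (0.11 log units; that floor lies within the scatter), with methyl in place of hydrogen. That step gives no firm size or direction to build on, so only a slight drop in this assay, inside the scatter, is expected. The expected change is a 1.3-fold lower number from compound 3 to compound 4 (0.11 log units; within the scatter). For compound 4 the estimate is 30000 nM, with an expected range of 12000 nM to 50000 nM.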

Compound 4, half-maximal inhibitory concentration: 33400 nM
The estimate for compound 4 lay 1.1-fold (0.05 log units) below the measured number; measured number inside the range.
By their numbers in this assay, from the lowest: compounds 4, 1 and 3 (each within the scatter of the next). At a limit, above all of these: compound 2.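

Replacing methyl with sec-butyl on this saturated chain carbon, a larger group with a defined stereocentre, gives no readable change (a 1.1-fold lower number from compound 3 to compound 4 (0.06 log units; within the scatter)). At the other site, (tert-butyl)amino in place of methyl on an aromatic carbon also gives no readable change (a 1.1-fold lower number from compound 1 to compound 4 (0.03 log units; within the scatter)). The step with sec-butyl in place of hydrogen (an at least 1.4-fold lower number from compound 2 to compound 4 (0.17 log units; that floor lies within the scatter)) gives only a floor, and it rests on a limit, not a number: the limit of > 50000 nM in this assay, at which 1 of the 4 values shown sits.

From the compounds shown here alone, how an amine or a carboxylic acid on this chain carbon would read remains open. So does a longer chain there.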